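This account rests on a few compounds, and the source may have more. Where it says the series, first, only, none or still open, it means among the compounds named here.

In an ADME assay on liver (Rattus norvegicus, strain Wistar) for metabolic stability, read by HPLC, tested at 200 uM (on this read-out lower numbers stand for a shorter-lived compound and higher numbers for a longer-lived compound), three compounds sharing one core have been measured. Compound 1, `Cc1cc(OC(=O)c2ccc(CC(CO[N+](=O)[O-])O[N+](=O)[O-])cc2)n(-c2ccccc2)n1`, gives < 0.0167 h, which is a limit of the assay and not a number. Compound 2, `Cc1cc(OC(=O)OCCCCCCO[N+](=O)[O-])n(-c2ccccc2)n1`, gives < 0.0167 h, again a limit and not a number. Going by these compounds, compound 2 thus stands at the limit of < 0.0167 h in this assay, at which 2 of the 3 values shown sit, and its true half-life remains unknown. Within the data shown here, compound 3, `Cc1cc(OC(=O)C(C)(C)CCC(CO[N+](=O)[O-])O[N+](=O)[O-])n(-c2ccccc2)n1`, is the only one with a number, 0.05 h.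

Compound 4, `Cc1cc(OC(=O)OCCCCC(CO[N+](=O)[O-])O[N+](=O)[O-])n(-c2ccccc2)n1`, has yet to be measured. It differs from compound 2 by a single change, nitrooxy in place of hydrogen on a saturated chain carbon bound to two saturated chain carbons, turning 2-(nitrooxy)ethyl into 1,2-bis(nitrooxy)ethyl.

Among the measured compounds shown here, no measured pair isolates this change in this assay, so only neighbouring compounds can guide the expectation. Compound 1 also carries 1,2-bis(nitrooxy)ethyl and still gives < 0.0167 h, a limit. Compound 3 carries the same group and gives 0.05 h. Little or no change is therefore expected, and no firm direction can be assigned. The expected step that the limit leaves unreadable from compound 2 to compound 4 is estimated to stay within the usual scatter. The half-life expected for compound 4 is 0.015 h, with an estimated range of 0.006 h to 0.05 h.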

Compound 4, half-life in the liver assay: < 0.0167 h
Compound 4: only a limit was reported; the forecaster's own chance of this, stated with the estimate: 70%; the middle value lies beyond the limit too.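

In the liver assay compound 4 gives < 0.0167 h, which is a limit and not a number. In the liver assay compound 2 gives < 0.0167 h, again a limit and not a number. In the liver assay this leaves a step that the two limits leave unreadable from compound 2 to compound 4, and both compounds stand at the same place: the limit of < 0.0167 h in the liver assay, at which 3 of the 4 values shown sit.

In a physicochemical assay for lipophilicity, read by HPLC, measured as octanol-water partition, at pH 7 (on this read-out lower numbers stand for lower lipophilicity and higher numbers for higher lipophilicity), compound 2 gives 4.39 and compound 4 gives 4.63. In the physicochemical assay that is a number 0.24 log units higher from compound 2 to compound 4 (within the scatter).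

The compounds shown leave open how long compound 2 and compound 4 actually last in the liver assay.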